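Working notes: aryl exchange from compound 2 to compound 3

This account rests on a few compounds, and the source may have more. Where it says the series, first, only, none or still open, it means among the compounds named here.

Measured so far in a functional assay on OVCAR-5 cells (Homo sapiens) for inhibition; a higher number here means a weaker inhibitor of growth, a lower number a stronger inhibitor of growth:
compound 1 `COc1ccc(-c2cn(-c3cccc(C(=O)/C=C/c4cc(OC)c(OC)c(OC)c4)c3)c(=O)[nH]2)cc1` — 2640 nM
compound 2 `COc1cc(/C=C/C(=O)c2cccc(-n3cc(-c4ccc(Cl)cc4)[nH]c3=O)c2)cc(OC)c1OC` — 3110 nM

Compound 2 holds the higher of the two numbers, yet the step of a 1.2-fold higher number from compound 1 to compound 2 (0.07 log units; within the scatter) sits within the scatter, so compound 1 and compound 2 cannot be told apart on these data. Compound 3 `COc1cc(/C=C/C(=O)c2cccc(-n3cc(-c4cc(OC)c(OC)c(OC)c4)[nH]c3=O)c2)cc(OC)c1OC` has not yet been measured in this assay. It differs from compound 2 by 3,4,5-trimethoxyphenyl in place of 4-chlorophenyl on an aromatic carbon. For the measured compounds named here, the one measured step, a 1.2-fold higher number from compound 1 to compound 2 (0.07 log units; within the scatter), concerns the same aromatic carbon, where chloro in place of methoxy left the number within the scatter; no measured step shows what 3,4,5-trimethoxyphenyl itself does at this position. The expectation for compound 3 is therefore a step of a 1.1-fold lower number from compound 2 to compound 3 (0.05 log units; within the scatter) of no size beyond the scatter. Compound 3 is estimated at 2800 nM, with a range of 1100 nM to 7500 nM.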

Compound 3, concentration for 50% growth inhibition: 4380 nM
The estimate for compound 3 lay 1.6-fold (0.19 log units) below the measured number; the measured number falls inside the stated range.
By their numbers in this assay, from the lowest: compounds 1, 2 and 3 (each within the scatter of the next).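

In this assay, the exchange on this aromatic carbon gives a 1.4-fold higher number from compound 2 to compound 3 (0.15 log units; within the scatter), and the companion exchange of 4-methoxyphenyl for 3,4,5-trimethoxyphenyl gives a 1.7-fold higher number from compound 1 to compound 3 (0.22 log units; within the scatter). For the compounds shown here, both steps lie within the scatter, so 4-methoxyphenyl, 4-chlorophenyl and 3,4,5-trimethoxyphenyl cannot be told apart at this position, although the earlier pair covered only a single change of the group on the aryl ring. The aryl group here can thus carry three methoxy groups without a step beyond the scatter, and no measurement at hand explains this flat result. As far as these compounds go, whether an amine or a carboxylic acid on this aromatic carbon would move the number beyond the scatter remains open. Also open, from the compounds shown here alone, is whether any change elsewhere in the shared core would do so, since all three compounds keep it unchanged.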